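The source may report more compounds than this note shows. Statements on the series, on what has been measured and on what is new or still open speak of the compounds shown alone.

Working notes on the series.

Compound 1 `COc1cc(-c2cc(/C=C/C(=O)c3ccc(N)cc3)[nH]n2)cc(OC)c1OC` gives 90% in a functional assay on SK-MEL-28 cells (Homo sapiens) for cytotoxicity, read by sulforhodamine B assay, with a stated time of 48 h, tested at 1 uM; on this read-out lower numbers stand for a stronger effect and higher numbers for a weaker effect at the one concentration tested. Compound 2 `COc1ccc(-c2cc(/C=C/C(=O)c3ccc(N)cc3)[nH]n2)cc1OC` gives 89% in this assay. The change between these two, (hydrogen in place of methoxy on an aromatic carbon), makes a number 1 percentage points lower from compound 1 to compound 2 (within the scatter). Compound 3 `COc1cc(C(=O)/C=C/c2cc(-c3cc(OC)c(OC)c(OC)c3)n[nH]2)cc(OC)c1OC` gives 100% in this assay; this number is the highest of the three, it lies within the scatter of the value of compound 1 and beyond the scatter of the value of compound 2. The difference between the core of compound 1 and the core of compound 3 is not broken down here.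

Compound 4 `COc1ccc(-c2cc(/C=C/C(=O)c3cc(OC)c(OC)c(OC)c3)[nH]n2)cc1OC` has not yet been measured in this assay. The change from compound 3 to compound 4, (hydrogen in place of methoxy on an aromatic carbon), is the same change as that from compound 1 to compound 2, and its surroundings are described in the same words. The step from compound 3 to compound 4 in this assay is expected to be small, about a number 1 percentage points lower from compound 3 to compound 4 (within the scatter), because the same change made a number 1 percentage points lower from compound 1 to compound 2 (within the scatter). Compound 4 is accordingly estimated at 99%, with a range from 89% to 106%.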

Compound 4, a percentage reported as activity, at one concentration (the size of the read-out at that concentration, not a potency): 89%
Compound 4: middle estimate off by 10 percentage points, on the high side; the measured number falls inside the stated range.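

In this assay, putting hydrogen in place of methoxy on an aromatic carbon makes a number 11 percentage points lower from compound 3 to compound 4 (beyond the scatter), while the same change on the other core makes a number 1 percentage points lower from compound 1 to compound 2 (within the scatter). Set side by side, the two steps do not differ by more than the scatter allows: the same change on two cores in this assay, a number 1 percentage points lower (within the scatter) from compound 1 to compound 2 and a number 11 percentage points lower (beyond the scatter) from compound 3 to compound 4, 10 percentage points apart, within the scatter of two such steps. The change can therefore be carried between these two cores without a readable difference in the step, but one pair on each core does not show that the step is the same on both, and it gives no cause for the size of either step.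

The compounds shown carry only methoxy or hydrogen at this place, so the effect of a fluorine, an amine or a longer chain such as ethoxy there remains open. On these data alone, whether the step holds at other concentrations, or on cores beyond these two, also remains open.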